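A methyl-to-ethyl change on the thioether aryl ring

A few compounds are considered here, and "the series" means these few. Any claim that something is new, unique, unknown or untested is made for them only; others in the source may bear on it.

The three measured compounds and their readings in a functional assay on A-375 cells (Homo sapiens) for inhibition, read by CCK-8 assay, with a stated time of 72 h, tested at 2 uM (a lower number here means less inhibition of growth, a higher number more inhibition of growth at the concentration tested), are:

compound 1, `Cc1ccc(SCc2ccc(/C=C/C(=O)Nc3ccccc3N)cc2)cc1`, gives 22.9%
compound 2, `COc1ccc(SCc2ccc(C(=O)Nc3ccccc3N)cc2)cc1`, gives 10.2%
compound 3, `COc1ccc(SCc2ccc(C(=O)Nc3ccccc3N)cc2)cc1OC`, gives 18.1%

Compound 1 holds the highest of the three numbers in this assay, though the gap to compound 3 lies within the scatter; only the gap to compound 2 lies beyond it. For the measured compounds named here, the one step between compounds that differ in a single place is a number 7.9 percentage points higher from compound 2 to compound 3 (within the scatter), a change that sits on a different part of the shared core and tells nothing about the ring that carries the thioether.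

Compound 4, `CCc1ccc(SCc2ccc(/C=C/C(=O)Nc3ccccc3N)cc2)cc1`, differs from compound 1 in one place: methyl in place of hydrogen on a saturated chain carbon bound to an aromatic carbon. Going by the values given here, no measured step touches this part of the structure, so the account can only note that the sole step seen, from compound 2 to compound 3, stayed within the scatter, and that a small added group here is expected to behave alike. The expected change is a number 1.1 percentage points higher from compound 1 to compound 4 (within the scatter), that is, none beyond the scatter. For compound 4 the estimate in this assay is 24%, with a range from 12% to 36%.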

Compound 4, percent growth inhibition at one concentration: 5.27%
The estimate for compound 4 lay 18.7 percentage points above the measured number, outside the stated range (below it).
By their numbers in this assay, from the lowest: compounds 4, 2, 3 and 1 (each within the scatter of the next, the first and the last beyond it).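

Methyl to ethyl on the thioether aryl ring, a change of a single added carbon, gave a number 17.6 percentage points lower from compound 1 to compound 4 (beyond the scatter) in this assay. This is the first one-place step shown that lies beyond the scatter, and it shows that the growth inhibition reading responds to the group at this position, which the single earlier step, made elsewhere on the shared core, could not reveal. Nothing shown bears on why the number falls with this change.

From the compounds shown here alone, with only 4-methylphenyl and 4-ethylphenyl compared on this core, it remains open whether a longer chain such as propyl, or an amine or a carboxylic acid at this place, would give a lower number or restore the reading. Also open, going by these compounds, is whether the same methyl-to-ethyl change would have a similar effect on the core of compound 2, or at other concentrations.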